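This account rests on a few compounds, and the source may have more. Where it says the series, first, only, none or still open, it means among the compounds named here.

Series notes. The shared core of compound 1 `CCCCNCCOc1c(O)cc(O)c2c(=O)cc(-c3ccccc3)oc12` carries a basic side chain through an ether oxygen on the aromatic ring, and compound 2 `O=c1cc(-c2ccccc2)oc2c(OCCNCCO)c(O)cc(O)c12` and compound 3 `CN(C)CCCCOc1c(O)cc(O)c2c(=O)cc(-c3ccccc3)oc12` vary that chain. In a functional assay on A549 cells (Homo sapiens) for cytotoxicity, read by MTT assay, with a stated time of 48 h (a lower number here means a stronger inhibitor, a higher number a weaker inhibitor), compound 1 gives "not determined" (no result reported). In this assay compound 2 likewise gives "not determined" (no result reported). For compound 3 the read-out in this assay is only a limit of the assay, > 100000 nM, and not a number. Compound 3 thus stands at the edge of what this assay reports, as the limit of > 100000 nM in this assay, at which 1 of the 3 values shown sits, shows. Among the measured compounds shown here, no step between two measured numbers exists in the set to calibrate against.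

Compound 4 `CN(C)CCCOc1c(O)cc(O)c2c(=O)cc(-c3ccccc3)oc12` is the next entry. Relative to compound 3 the change is dimethylamino in place of (dimethylamino)methyl on a saturated chain carbon, three bonds along the chain from an oxygen on an aromatic ring; cut one bond further out it reads 4-(dimethylamino)butyl to 3-(dimethylamino)propyl. Since compound 3 sits at a limit in this assay, no shift beyond the scatter is expected in either direction. The expected step is a number no higher from compound 3 to compound 4 (the limit leaves the size open), essentially flat. Compound 4 is therefore expected to give about 100000 nM in this assay, with a range of 30000 nM to 300000 nM, and most likely only a limit again rather than a number.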

Compound 4, half-maximal inhibitory concentration: > 100000 nM
Compound 4 gave a limit, no number; the forecaster's own chance of this, stated with the estimate: 75%; the middle value sits exactly at the limit.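

Compound 3 and compound 4 both end at a limit in this assay and not at a number, so no step can be read between them: the limit of > 100000 nM in this assay, at which 2 of the 4 values shown sit.

The compounds shown leave open whether any side chain on the shared core gives a number in this assay at all, and how 4-(dimethylamino)butyl and 3-(dimethylamino)propyl truly compare.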